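The source may hold more compounds than are shown below. What is called first, only, known or untested is meant among the compounds shown, and "the series" means these compounds.

Measured so far:
- Compound 1 `COc1cc(-c2ccnc3cc(-c4ccc5c(ccn5C)c4)nn23)cc(OC)c1OC`: 48 nM
- Compound 2 `COc1cc(-c2ccnc3cc(-c4ccc5cc[nH]c5c4)nn23)cc(OC)c1OC`: 55 nM

In a functional assay on B16-F0 cells (Mus musculus) for inhibition, read by CCK-8 assay, with a stated time of 48 h (on this read-out lower numbers stand for stronger inhibition and higher numbers for weaker inhibition), compound 2 gives 55 nM, level with compound 1 within the scatter. Compound 3 `COc1ccc(-c2cc3nccc(-c4cc(OC)c(OC)c(OC)c4)n3n2)cc1` has 4-methoxyphenyl in place of 1H-indol-6-yl on an aromatic carbon. Among the compounds with values here, the only measured step, a 1.1-fold higher number from compound 1 to compound 2 (0.06 log units; within the scatter), exchanged one indole group for another, so it offers weak guidance for removing the indole altogether. A moderately weaker result in this assay is therefore expected, though with wide uncertainty. The expected change is a 2.7-fold higher number from compound 2 to compound 3 (0.44 log units; beyond the scatter). Compound 3 is estimated at 150 nM, with an expected range of 35 nM to 700 nM.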

Compound 3, half-maximal inhibitory concentration: 1410 nM
Estimate against measurement, compound 3: 9.4-fold (0.97 log units) below, and the stated range ends below it.
By their numbers in this assay, from the lowest: compounds 1 and 2 (each within the scatter of the next); then compound 3.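

In this assay, this aromatic carbon of the shared core accepts both indole groups about equally, but the change to 4-methoxyphenyl gives a 26-fold higher number from compound 2 to compound 3 (1.41 log units; beyond the scatter) and a 29-fold higher number from compound 1 to compound 3 (1.47 log units; beyond the scatter). The indole groups are therefore not interchangeable here with this single-ring group, a sensitivity that the indole-for-indole step could not reveal. No measurement here explains the loss.

The compounds shown leave open whether the loss follows from removing the indole's five-membered ring or from adding the methoxy group. A plain phenyl or a 4-aminophenyl group at this carbon would help separate those two changes.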